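The source may report more compounds than this note shows. Statements on the series, on what has been measured and on what is new or still open speak of the compounds shown alone.

Compound 1 `CCCCCCNC(=O)CN1CC(=O)N(C)[C@@H](Cc2ccc(-c3cc(OC)c(OC)c(OC)c3)cc2)C1=O` gives 3 nM in a functional assay for agonist activity at follicle-stimulating hormone receptor (Homo sapiens), read by a luciferase reporter (on this read-out lower numbers stand for an effect already at smaller amounts and higher numbers for an effect only at larger amounts of compound), the second highest of three numbers: compound 2 `CCCCCNC(=O)CN1CC(=O)N(C)[C@@H](Cc2ccc(-c3cccc(CN(CCCC)C(=O)NC)c3)cc2)C1=O` gives 1.7 nM, a gap within the scatter, while compound 3 `CCCCCCCCCN1CC(=O)N(C)[C@@H](Cc2ccc(-c3cc(OC)c(OC)c(OC)c3)cc2)C1=O` gives 900 nM. Going by the values given here, the measured step of a 300-fold higher number from compound 1 to compound 3 (2.48 log units; beyond the scatter) is the only one that bears on compound 4 `CCCCCCCCN1CC(=O)N(C)[C@@H](Cc2ccc(-c3cc(OC)c(OC)c(OC)c3)cc2)C1=O`, whose change is heptyl in place of hexylcarbamoyl on a saturated chain carbon bound to an amide-type nitrogen in a ring; that is the same exchange of the amide-bearing chain for a plain chain, only one carbon shorter, so a step of similar size in the same direction is expected, though with no measurement of a heptyl chain its exact size is uncertain. Compound 4 is therefore estimated at 800 nM, between 150 nM and 4000 nM, an expected step of a 270-fold higher number from compound 1 to compound 4 (2.43 log units; beyond the scatter).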

Compound 4, half-maximal effective concentration: 400 nM
Compound 4: middle estimate off by 2.0-fold (0.30 log units), on the high side; low and high end bracket the measured number.
By their numbers in this assay, from the lowest: compounds 2 and 1 (each within the scatter of the next); then compound 4; then compound 3.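

A second plain chain brings a large loss as well: heptyl in place of hexylcarbamoyl gives a 130-fold higher number from compound 1 to compound 4 (2.12 log units; beyond the scatter) in this assay, so the loss is not peculiar to octyl. Chain length also counts here, though much less, as trimming the plain chain gives a 2.3-fold lower number from compound 3 to compound 4 (0.35 log units; beyond the scatter) and still leaves compound 4 far from compound 1. Nothing available explains either change. Open still is whether a shorter plain chain, such as pentyl, would lower the number further, and whether a chain ending in an amine or a carboxylic acid would match compound 1.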